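Bromo Replaces Hydrogen on the Phenyl of a Triazole Carbamate

A few compounds are considered here, and "the series" means these few. Any claim that something is new, unique, unknown or untested is made for them only; others in the source may bear on it.

Measured compounds:
Compound 1, `O=C(N1C[C@H](O)C=C[C@H]1COCc1ccccc1)n1cc(-c2ccc(-c3ccccc3)cc2)nn1`, 316 nM
Compound 2, `O=C(N1CCC=C[C@@H]1COCc1ccccc1)n1cc(-c2ccccc2)nn1`, 158 nM

Both compounds were tested in an assay on HEK293 cells for inhibition of Monoacylglycerol lipase ABHD6 (Homo sapiens), read by fluorescence; on this read-out lower numbers stand for stronger inhibition and higher numbers for weaker inhibition. Compound 1 gives 316 nM, and compound 2 gives 158 nM. Of the two numbers, compound 2 holds the lower one, but the gap to compound 1 lies within the usual scatter of repeated measurements, so no order between the two can be claimed. The two compounds also differ in more than one place, so their pair teaches nothing about a single structural change.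

Compound 3, `O=C(N1CCC=C[C@@H]1COCc1ccccc1)n1cc(-c2ccc(Br)cc2)nn1`, has not yet been measured in this assay. It is built on the core of compound 2 with one change, (bromo in place of hydrogen on an aromatic carbon). Among the measured compounds shown here, no measured pair shows what this change does here. With nothing to lean on beyond compound 2 itself, the step from compound 2 to compound 3 is expected to be small, with a slight lean toward a lower number, and is estimated at a 1.2-fold lower number from compound 2 to compound 3 (0.08 log units; within the scatter). Compound 3 is therefore expected to give about 130 nM, within a range of 40 nM to 400 nM.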

Compound 3, half-maximal inhibitory concentration: 15.9 nM
For compound 3 the middle estimate is 8.2-fold (0.91 log units) above the measured one; the measured number lies below the stated range.
By their numbers in this assay, from the lowest: compound 3; then compounds 2 and 1 (each within the scatter of the next).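

In this assay, putting bromo in place of hydrogen on the aromatic ring, para to a large group, gives a 9.9-fold lower number from compound 2 to compound 3 (1.00 log units; beyond the scatter), a step well beyond the usual scatter. The earlier pair differed in more than one place and could say nothing about any single change, whereas this pair differs in one place only and shows that this position on the phenyl is not indifferent: a change of one heavy atom, adding no ring, no hydrogen-bond donor or acceptor and no charge, is enough to move the number clearly. No measurement shown here speaks to what lies behind this step.

The compounds shown leave open whether bromine itself matters or whether other groups at the same place, such as chloro, methyl, methoxy, an amine or a carboxylic acid, would move the number as far, or in the opposite direction. They also leave open whether phenyl to 4-bromophenyl would give a step of similar size on a different core, such as the core of compound 1.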